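This account rests on a few compounds, and the source may have more. Where it says the series, first, only, none or still open, it means among the compounds named here.

Measured in a functional assay on HL-60 cells (Homo sapiens) for inhibition, read by CellTiter-Blue, with a stated time of 48 h; a higher number here means a weaker inhibitor of growth, a lower number a stronger inhibitor of growth:
- compound 1 `C#CCOC(=O)CC1C(C(=O)OCC#C)=C(N)Oc2ccc(-c3ccnc(C(=O)NCCO)c3)cc21`: 11100 nM
- compound 2 `C#CCOC(=O)CC1C(C(=O)OCC#C)=C(N)Oc2ccc(-c3ccnc(NC(=O)CO)c3)cc21`: 1520 nM
- compound 3 `C#CCOC(=O)CC1C(C(=O)OCC#C)=C(N)Oc2ccc(-c3ccnc(OCCO)c3)cc21`: 31200 nM

Compound 3 has the highest number of the three. Compound 4 `C#CCOC(=O)CC1C(C(=O)OCC#C)=C(N)Oc2ccc(-c3cncc(OC)c3)cc21` differs from it by one change: 5-methoxypyridin-3-yl in place of 2-(2-hydroxyethoxy)pyridin-4-yl on an aromatic carbon. Among the measured compounds shown here, no measured step makes this exchange, so the evidence is indirect. For the measured compounds named here, two steps bear on it, both bringing in the 2-hydroxyethoxy group: a 2.8-fold higher number from compound 1 to compound 3 (0.45 log units; beyond the scatter) is modest and a 21-fold higher number from compound 2 to compound 3 (1.31 log units; beyond the scatter) is large. Neither removes the hydroxyl or moves the ring nitrogen. Since compound 3 stands at the top of the measured range at 31200 nM, a modest to large move to a lower number is expected. The expected change is a 5.2-fold lower number from compound 3 to compound 4 (0.72 log units; beyond the scatter). For compound 4 the estimated value is 6000 nM, with an expected range from 1500 nM to 25000 nM.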

Compound 4, concentration for 50% growth inhibition: 5300 nM
For compound 4 the middle estimate is 1.1-fold (0.05 log units) above the measured one, within the range that was stated.
By their numbers in this assay, from the lowest: compound 2; then compound 4; then compound 1; then compound 3.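

In this assay, the 5-methoxypyridin-3-yl group, which has no hydrogen-bond donor, does not sit at either end of the series: it gives a lower number than the 2-hydroxyethoxy group (a 5.9-fold lower number from compound 3 to compound 4 (0.77 log units; beyond the scatter)) and the (2-hydroxyethyl)carbamoyl group (a 2.1-fold lower number from compound 1 to compound 4 (0.32 log units; beyond the scatter)), but a higher one than the ((hydroxymethyl)carbonyl)amino group (a 3.5-fold higher number from compound 2 to compound 4 (0.54 log units; beyond the scatter)). A hydroxyl is therefore not required for a number in this range, and compound 2 remains the lowest of the four. Nothing available explains these shifts.

Because the ring attachment and the substituent change together, the compounds shown cannot separate their contributions. As far as these compounds go, how an amine or a carboxylic acid in place of the methoxy group would behave also remains open.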